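The source may report more compounds than this note shows. Statements on the series, on what has been measured and on what is new or still open speak of the compounds shown alone.

Compound 1 `CC(C)[C@H](C[C@H]1OC(=O)NC1=O)c1ccc(-c2ccc3cccc(F)c3c2)[nH]c1=O`: 10.3 10^-6 cm/s
Compound 2 `CC(C)C(c1ccc(-c2ccc3cccc(F)c3c2)[nH]c1=O)C1C(=O)NC(=O)N1C`: "not determined" (no result reported)

In an ADME assay on MDCK cells (Canis lupus familiaris) for permeability, in the apical to basolateral direction (a higher number here means that the compound crosses the layer faster, a lower number that the compound crosses the layer more slowly), compound 1 gives 10.3 10^-6 cm/s. For compound 2, the entry in this assay reads "not determined" (no result reported), so compound 2 stands on no number of its own. Compound 3 `CC(C)C(/C=C1/C(=O)NC(=O)N1C)c1ccc(-c2ccc3cccc(F)c3c2)[nH]c1=O` remains to be measured. It differs from compound 2 by a group of 9 heavy atoms (5 carbon, 2 nitrogen, 2 oxygen; one five-membered non-aromatic ring with 2 hetero atoms) in place of a group of 8 heavy atoms (4 carbon, 2 nitrogen, 2 oxygen; one five-membered non-aromatic ring with 2 hetero atoms), on a saturated chain carbon bound to an aromatic carbon and a saturated chain carbon. For the measured compounds named here, no measured step frames this change, and compound 2 has no value, so the data give no direction for this assay; the expectation is of a step within the usual scatter, in no fixed direction. Compound 3 is therefore expected near 9 10^-6 cm/s, within a range of 3 10^-6 cm/s to 22 10^-6 cm/s.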

Compound 3, apparent permeability: 14.1 10^-6 cm/s
The estimate for compound 3 lay 1.6-fold (0.19 log units) below the measured number, and the stated range covers the measured number.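

For the compounds shown here, compound 2 has no number to set beside compound 3 in this assay, so no step between them can be read. The compounds shown leave open how replacing the 3-methyl-2,5-dioxoimidazolidin-4-yl group shifts apparent permeability. No evidence at hand bears on this result.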